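The source may report more compounds than this note shows. Statements on the series, on what has been measured and on what is new or still open speak of the compounds shown alone.

Two compounds share one core in which a cyclohexylamino group and an aryl ring sit on the same five-membered ring. In an assay on cells for inhibition of Polyunsaturated fatty acid 5-lipoxygenase (Homo sapiens), read by HPLC, with stated times of 15 min and 10 min (on this read-out lower numbers stand for stronger inhibition and higher numbers for weaker inhibition), compound 1 `Cc1ccc2nc(-c3ccc([N+](=O)[O-])cc3)c(NC3CCCCC3)n2c1` gives 1530 nM. Compound 2 `Cc1ccc2nc(-c3ccncc3)c(NC3CCCCC3)n2c1` gives 7200 nM in this assay, the highest of the two numbers, its gap to compound 1 lying beyond the scatter. Compound 3 `COc1ccc(-c2nc3ccc(C)cn3c2NC2CCCCC2)cc1` differs from compound 2 by 4-methoxyphenyl in place of pyridin-4-yl on an aromatic carbon. Because compound 1 gives 1530 nM with a ring of carbon only, the step of a 4.8-fold lower number from compound 2 to compound 3 (0.68 log units; beyond the scatter) is expected to lower the number beyond the scatter. Compound 3 is estimated at 1500 nM, within 500 nM to 5000 nM.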

Compound 3, half-maximal inhibitory concentration: 1300 nM
For compound 3 the middle estimate is 1.2-fold (0.06 log units) above the measured one; measured number inside the range.
By their numbers in this assay, from the lowest: compounds 3 and 1 (each within the scatter of the next); then compound 2.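

In this assay, 4-methoxyphenyl in place of pyridin-4-yl gives a 5.5-fold lower number from compound 2 to compound 3 (0.74 log units; beyond the scatter), so a second compound with a ring of carbon only now stands apart from compound 2. Methoxy in place of nitro gives a 1.2-fold lower number from compound 1 to compound 3 (0.07 log units; within the scatter), so compound 1 and compound 3 cannot be told apart, although the two groups differ. Nothing measured here explains these results. Still open, as far as these compounds go, is whether a plain phenyl ring, with neither methoxy nor nitro, would match them, and how an amine or a carboxylic acid on that ring would read.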